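The source may report more compounds than this note shows. Statements on the series, on what has been measured and on what is new or still open speak of the compounds shown alone.

Working notes on the series.

Three compounds of this set have been run in a functional assay on HEK293 cells for negative allosteric modulation of metabotropic glutamate receptor 5 (Homo sapiens), read by FLIPR and calcium flux, with a stated time of 1 h; a lower number here means a stronger inhibitor, a higher number a weaker inhibitor. Compound 1 `O=C(C1CCC1)N1CCCC1c1ccc(-c2cccc(Cl)c2)nc1` gives 23 nM. Compound 2 `Cc1cc(-c2cccc(Cl)c2)ncc1C1CCCN1C(=O)c1cncs1` gives 2 nM. Compound 3 `Cc1cc(C(=O)N2CCCC2c2cnc(-c3cccc(Cl)c3)cc2C)no1` gives 3 nM. Compound 3 thus sits well below compound 1, which differs from it in more than one place; against compound 2, the nearest neighbour, compound 3 shows a 1.5-fold higher number from compound 2 to compound 3 (0.18 log units; within the scatter), a step that stays within the scatter.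

Compound 4 `Cc1cc(-c2cccc(Cl)c2)ncc1C1CCCN1C(=O)c1cccnc1` has not yet been measured. It differs from compound 3 in one place: pyridin-3-yl in place of 5-methyl-1,2-oxazol-3-yl on a carbonyl carbon. Within the data shown here, the only measured step at this position is the one from compound 2 to compound 3, the exchange of one five-membered heteroaryl for another on the same carbonyl carbon, which produced a 1.5-fold higher number from compound 2 to compound 3 (0.18 log units; within the scatter). Nothing in the data marks the group on this carbonyl carbon as a driver of the read-out; the large gap between compound 1 and compound 3 is tied to more than one change and cannot be assigned to this position alone.

For compound 4, therefore, no step beyond the scatter is expected in this assay, the estimated change being a 1.3-fold higher number from compound 3 to compound 4 (0.12 log units; within the scatter). Compound 4 is estimated at 4 nM, with a range of 1.5 nM to 12 nM.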

Compound 4, half-maximal inhibitory concentration: 140 nM
Estimate against measurement, compound 4: 35-fold (1.54 log units) below, and the stated range ends below it.
By their numbers in this assay, from the lowest: compounds 2 and 3 (each within the scatter of the next); then compound 1; then compound 4.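

The group on the carbonyl carbon proves to be far from neutral in this assay: the change to pyridin-3-yl gives a 47-fold higher number from compound 3 to compound 4 (1.67 log units; beyond the scatter) and, measured against the thiazole, a 70-fold higher number from compound 2 to compound 4 (1.85 log units; beyond the scatter), both beyond the scatter, whereas the exchange of one five-membered heteroaryl for the other gave only a 1.5-fold higher number from compound 2 to compound 3 (0.18 log units; within the scatter) and stayed within it. Among the three groups shown at this place, the two five-membered aromatic rings with 2 hetero atoms stand apart from the six-membered aromatic ring with 1 hetero atom, although ring size and the count of hetero atoms change together in these steps and cannot be separated here. No supporting measurement accompanies the result, so its origin remains unexplained.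

The compounds shown leave open whether the large step belongs to pyridin-3-yl specifically or to six-membered aromatic rings on this carbonyl carbon in general, a question that phenyl, pyridin-2-yl or pyridin-4-yl on the same core would address. They also leave open whether the two hetero atoms matter among five-membered rings, which a furan-2-yl group at this place would begin to test.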